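The source may hold more compounds than are shown below. What is called first, only, known or untested is meant among the compounds shown, and "the series" means these compounds.

Working notes on the series. In a functional assay on A2780 cells (Homo sapiens) for antiproliferative activity, read by fluorescence, with a stated time of 72 h (on this read-out lower numbers stand for stronger inhibition and higher numbers for weaker inhibition), compound 1 (`CC1(C)c2[nH]nc(NC(=O)c3ccc(F)cc3)c2CN1C(=O)C1CCN(C2CC2)CC1`) gives 380 nM, compound 2 (`CN1CCC(C(=O)N2Cc3c(NC(=O)c4cc(F)cc(F)c4)n[nH]c3C2(C)C)CC1`) gives 130 nM and compound 3 (`CN1CCC(C(=O)N2Cc3c(NC(=O)c4cccs4)n[nH]c3C2(C)C)CC1`) gives 30 nM. Compound 3 therefore holds the lowest number of the three, and its gaps to both of the others lie beyond the scatter.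

The next compound to read is compound 4 (`CN1CCC(C(=O)N2Cc3c(NC(=O)c4ccncc4)n[nH]c3C2(C)C)CC1`), with pyridin-4-yl in place of thiophen-2-yl on a carbonyl carbon.

For the measured compounds named here, only one measured step bears on this place, a 4.3-fold lower number from compound 2 to compound 3 (0.64 log units; beyond the scatter), which put thiophen-2-yl in place of 3,5-difluorophenyl on the same carbonyl carbon. That step is modest but beyond the scatter, so the group on this carbonyl carbon can shift the number in this assay. Going by the values given here, no measured compound carries pyridin-4-yl, so the direction rests on thin evidence. Among the compounds with values here, compound 3, at 30 nM, is the only measured compound with thiophen-2-yl and holds the lowest number, so replacing that group is expected to give a higher number rather than a lower one.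

The expected change, of about the same modest size as the measured step, is a 3.3-fold higher number from compound 3 to compound 4 (0.52 log units; beyond the scatter). In this assay the estimated value for compound 4 is 100 nM, with an expected range of 35 nM to 300 nM.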

Compound 4, half-maximal inhibitory concentration: 500 nM
Beside the measured number, compound 4's estimate is 5.0-fold (0.70 log units) below it; measured number outside the range, above it.
By their numbers in this assay, from the lowest: compound 3; then compound 2; then compounds 1 and 4 (each within the scatter of the next).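

In this assay, the group on this carbonyl carbon now has three readings on an otherwise unchanged structure, and pyridin-4-yl in place of thiophen-2-yl gives a 17-fold higher number from compound 3 to compound 4 (1.22 log units; beyond the scatter), a large step where the earlier one at this place was modest. Compound 4 also lies on the far side of compound 2, with a 3.8-fold higher number from compound 2 to compound 4 (0.59 log units; beyond the scatter), so the order from the lowest number is thiophen-2-yl, 3,5-difluorophenyl, pyridin-4-yl, each step beyond the scatter. The counted features do not separate the pair in the large step, since thiophen-2-yl and pyridin-4-yl each hold one hetero atom, one hydrogen-bond acceptor, no hydrogen-bond donor and no net charge, which leaves ring size and the identity of the hetero atom as the differences on record.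

Three groups cannot show which of those two differences goes with the change in number, and a furan-2-yl or a pyridin-3-yl on the same carbonyl carbon would be the direct comparisons to set beside compound 3 and compound 4. Nothing at hand gives a measured reason for the size of the step from thiophen-2-yl to pyridin-4-yl.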